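The compounds below may be only part of what the source reports. "The series", "measured", "known", "first", "only" and "open" are said of these compounds alone.

In a physicochemical assay for solubility (a lower number here means a less soluble compound, a higher number a more soluble compound), compound 1 `CNC(=O)c1cc(C(=O)N[C@H]2[C@@H]3C[C@@H](O)C[C@@H]32)cc2c1OC[C@H]2c1ccccc1` gives >= 124 ug/mL, which is a limit and not a number. Compound 2 `CC[C@@]1(c2ccccc2)COc2c(C(=O)NC)cc(C(=O)N[C@H]3[C@@H]4COC[C@@H]43)cc21` gives >= 152 ug/mL, also a limit. For the measured compounds named here, compound 3 `CNC(=O)c1cc(C(=O)N[C@@H]2C[C@H]2C)cc2c1O[C@H](CF)[C@H]2c1ccccc1` gives 7 ug/mL, the only exact number among the three. Compound 4 `CNC(=O)c1cc(C(=O)N[C@H]2C[C@@H]2C)cc2c1OC[C@H]2c1ccccc1` differs from compound 1 in one place, on an amide-type nitrogen: a group of 4 heavy atoms (4 carbon; one three-membered non-aromatic ring of carbon only) in place of a group of 7 heavy atoms (6 carbon, 1 oxygen; one three-membered non-aromatic ring of carbon only, one five-membered non-aromatic ring of carbon only), on an amide-type nitrogen. A downward step in this assay, beyond the scatter, is expected, and the nearest guide is compound 3, which also carries a 2-methylcyclopropyl group and gives 7 ug/mL. The expected size is an at least 8.2-fold lower number from compound 1 to compound 4 (0.91 log units; beyond the scatter). For compound 4 the estimated value is 15 ug/mL, with an expected range of 5 ug/mL to 60 ug/mL.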

Compound 4, solubility: >= 76 ug/mL
Compound 4 was reported as a limit; the forecaster's own chance of this, stated with the estimate: 10%; middle value at least 5.0-fold (0.70 log units) from the limit.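

In this assay compound 4 gives >= 76 ug/mL, which is a limit. Compound 1 gives >= 124 ug/mL, also a limit, so no step can be read between these two compounds. The compounds shown leave open the size and direction of any change in this assay when 2-methylcyclopropyl stands on the amide-type nitrogen in place of the group in compound 1.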